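Three Limits, One Methyl Added Next to a Ring Nitrogen

The source may hold more compounds than are shown below. What is called first, only, known or untested is meant among the compounds shown, and "the series" means these compounds.

Compound 1 `CC(C)(C)c1cc(NC(=O)Nc2ccc(Nc3ncnc4c3OCCN4)cc2)no1` and compound 2 `Cc1cc(NC(=O)Nc2cc(C(C)(C)C)on2)ccc1Nc1ncnc2c1OCCN2` share a core and differ by methyl in place of hydrogen on an aromatic carbon. In a functional assay on BaF3 cells (Mus musculus) for inhibition, read by MTT assay, with a stated time of 3 days (a higher number here means a weaker inhibitor of growth, a lower number a stronger inhibitor of growth), compound 1 gives > 10000 nM, which is a limit of the assay rather than a number. Compound 2 in this assay gives > 10000 nM, again a limit. The step that the two limits leave unreadable from compound 1 to compound 2 therefore cannot be sized. Compound 3 `CC(C)(C)c1cc(NC(=O)Nc2ccc(Nc3ncnc4c3OCCN4)nc2)no1` carries a different core, and how its core differs from that of compound 1 is not broken down here. In this assay compound 3 gives > 10000 nM, also a limit. Going by the values given here, every measured value so far sits at the limit of > 10000 nM in this assay, at which 3 of the 3 values shown sit. Compound 4 `Cc1nc(Nc2ncnc3c2OCCN3)ccc1NC(=O)Nc1cc(C(C)(C)C)on1` has not yet been measured; it differs from compound 3 by methyl in place of hydrogen on an aromatic carbon. Among the compounds with values here, this is the same kind of change as the one from compound 1 to compound 2, but the surroundings differ: there the methyl entered on a six-membered aromatic ring of carbon only, here on a six-membered aromatic ring with 1 nitrogen, next to the ring nitrogen. Because all three earlier values rest at the limit of > 10000 nM in this assay, at which 3 of the 3 values shown sit, compound 4 is expected to give 20000 nM in this assay. The expected step is a step that the limit leaves unreadable from compound 3 to compound 4, most likely reported only as a limit.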

Compound 4, concentration for 50% growth inhibition: > 10000 nM
Compound 4 gave a limit, no number; the forecaster's own chance of this, stated with the estimate: 85%; the middle value lies beyond the limit too.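

In this assay compound 4 gives > 10000 nM as a limit and not a number. Going by these compounds alone, compound 3 also rests at a limit, so no step from compound 3 to compound 4 can be read. The compounds shown leave open how strongly each inhibits growth, and whether the methyl changes that, since all rest at one value: the limit of > 10000 nM in this assay, at which 4 of the 4 values shown sit.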